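The compounds below may be only part of what the source reports. "The series", "measured", "known", "first", "only" and "open" are said of these compounds alone.

Measured in an ADME assay on WI-38 cells (Homo sapiens) for inhibition, read by MTT assay, with a stated time of 72 h; on this read-out lower numbers stand for stronger inhibition and higher numbers for weaker inhibition:
- compound 1 `Cc1ccccc1C(=O)OC1(C(=O)Nc2ccc([N+](=O)[O-])cc2)CCCCC1` gives 352 nM
- compound 2 `O=C(OC1(C(=O)Nc2ccc([N+](=O)[O-])cc2)CCCCC1)c1ccc(Br)cc1` gives 523 nM
- compound 3 `O=C(OC1(C(=O)Nc2ccc([N+](=O)[O-])cc2)CCCCC1)c1ccccc1I` gives 396 nM

Compound 3 stands second highest of the three numbers; its nearest neighbour is compound 1 with a 1.1-fold higher number from compound 1 to compound 3 (0.05 log units; within the scatter), its furthest is compound 2 with a 1.3-fold lower number from compound 2 to compound 3 (0.12 log units; within the scatter). All three measured compounds share the same core and differ only in the aryl group on the ester carbonyl; every step among them lies within the scatter, including a 1.5-fold higher number from compound 1 to compound 2 (0.17 log units; within the scatter).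

Compound 4 `O=C(OC1(C(=O)Nc2ccc([N+](=O)[O-])cc2)CCCCC1)c1ccc([N+](=O)[O-])cc1` is not yet measured. It differs from compound 3 by 4-nitrophenyl in place of 2-iodophenyl on a carbonyl carbon. Among the measured compounds shown here, the steps that bear on this are the aryl swaps already seen, from compound 1 to compound 2 and from compound 2 to compound 3, both within the scatter; none of them involved a nitro-bearing aryl, so that part of the change has no precedent here. Given that, the step to compound 4 is expected to be small, with no direction beyond the scatter. The estimated step is a 1.1-fold higher number from compound 3 to compound 4 (0.03 log units; within the scatter). Compound 4 is estimated at 420 nM, with a range from 200 nM to 900 nM.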

Compound 4, half-maximal inhibitory concentration: 761 nM
Compound 4: middle estimate off by 1.8-fold (0.26 log units), on the low side; the range from low to high includes it.
By their numbers in this assay, from the lowest: compounds 1, 3, 2 and 4 (each within the scatter of the next, the first and the last beyond it).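

In this assay, 4-nitrophenyl on the carbonyl carbon gives the first step among these aryl swaps that passes the scatter, and it is a modest one: a 2.2-fold higher number from compound 1 to compound 4 (0.33 log units; beyond the scatter). The other two steps stay within the scatter, a 1.9-fold higher number from compound 3 to compound 4 (0.28 log units; within the scatter) and a 1.5-fold higher number from compound 2 to compound 4 (0.16 log units; within the scatter), so the nitro-bearing aryl group stands apart from only one of the three earlier groups, the 2-methylphenyl. No measurement at hand explains this gap.

From the compounds shown here alone, whether an aryl group carrying an amine or a carboxylic acid would stay within the same range remains open, as does the outcome of replacing the aryl group on the carbonyl carbon with a longer alkyl chain. Going by these compounds, it is also open whether the gap between 4-nitrophenyl and 2-methylphenyl would persist on a different core.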